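This account rests on a few compounds, and the source may have more. Where it says the series, first, only, none or still open, it means among the compounds named here.

Measured compounds:
- compound 1, `CC1(C)C2CCC1(C)C(OC(=O)/C=C/c1ccc(O)c(O)c1[N+](=O)[O-])C2`: 13900 nM
- compound 2, `O=C(/C=C/c1cc(O)c(O)c([N+](=O)[O-])c1)OCCc1ccccc1`: "not determined" (no result reported)

In a functional assay on HeLa cells (Homo sapiens) for inhibition, read by MTT assay (a lower number here means a stronger inhibitor, a higher number a weaker inhibitor), compound 1 gives 13900 nM. Compound 2 has no number in this assay, so it stands nowhere on the scale shown; it offers no anchor for the step to compound 3.

Compound 3, `O=C(/C=C/c1cc(O)c(O)c(Br)c1)OCCc1ccccc1`, differs from compound 2 by bromo in place of nitro on an aromatic carbon. With compound 2 unmeasured, no direction for this step can be read from the data; the change is not expected to carry the value far beyond the usual scatter from where a close analogue of compound 1 would sit.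

For the measured compounds named here, on the single measured value, compound 3 is expected at about 15000 nM, within 4000 nM to 60000 nM.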

Compound 3, half-maximal inhibitory concentration: 17500 nM
Compound 3: the middle estimate sits 1.2-fold (0.07 log units) below what was measured, and the stated range covers the measured number.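

No new step can be read from compound 2 to compound 3 in this assay. The compounds shown leave open how bromo in place of nitro shifts the value in this assay. No supporting evidence bears on this result.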